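This account rests on a few compounds, and the source may have more. Where it says the series, first, only, none or still open, it means among the compounds named here.

Compounds measured so far:
compound 1, `ClCCc1cc[nH]n1`: 200000 nM
compound 2, `ClCCCc1cc[nH]n1`: 40000 nM

In an assay for inhibition of alcohol dehydrogenase (Equus caballus), read by spectrophotometry, in the presence of a further agent that is not named here (on this read-out higher numbers stand for weaker binding and lower numbers for tighter binding), compound 2 gives the lowest of the two numbers, with compound 1 the nearest. The change from compound 2 to compound 3, `OCc1cc[nH]n1`, is hydroxy in place of 2-chloroethyl on a saturated chain carbon bound to an aromatic carbon. Among the compounds with values here, the only step on record runs the other way in chain length: a 5.0-fold lower number from compound 1 to compound 2 (0.70 log units; beyond the scatter). Removing the chain and putting a hydroxy in its place is therefore expected to raise the number in this assay by a modest step, a 15-fold higher number from compound 2 to compound 3 (1.18 log units; beyond the scatter). Compound 3 is estimated at 600000 nM, between 150000 nM and 3000000 nM.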

Compound 3, dissociation constant: 150000 nM
Compound 3: middle estimate off by 4.0-fold (0.60 log units), on the high side; the range from low to high includes it.
By their numbers in this assay, from the lowest: compound 2; then compounds 3 and 1 (each within the scatter of the next).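

In this assay, replacing 2-chloroethyl with hydroxy on a saturated chain carbon bound to an aromatic carbon loses the tighter binding of compound 2, with a 3.8-fold higher number from compound 2 to compound 3 (0.57 log units; beyond the scatter). Replacing chloromethyl with hydroxy at that carbon makes no difference beyond the scatter, with a 1.3-fold lower number from compound 1 to compound 3 (0.12 log units; within the scatter), so at this position only the 2-chloroethyl group stands apart so far. Nothing available explains these differences. The compounds shown leave open whether a longer chain or an amine at this carbon would bind more tightly than compound 2.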